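Pyridin-2-yl substituent swap in the diarylmethyl thiazole series

The compounds below may be only part of what the source reports. "The series", "measured", "known", "first", "only" and "open" are said of these compounds alone.

Compound 1 `O=C(O)Cc1sc(C(c2ccc(F)cc2)c2ccc(F)cc2)nc1-c1ccccc1` gives 240 nM in an in vitro functional assay on HEK285-7 cells for antagonist activity at prostaglandin D2 receptor 2 (Homo sapiens), read by BRET and beta-arrestin recruitment; on this read-out lower numbers stand for stronger inhibition and higher numbers for weaker inhibition. Compound 2 `O=C(O)Cc1sc(C(c2ccc(F)cc2)c2ccc(F)cc2)nc1-c1ccncc1` gives 40 nM, and compound 3 `O=C(O)Cc1sc(C(c2ccc(F)cc2)c2ccc(F)cc2)nc1-c1ccnc(O)c1` gives 890 nM, the highest of the three numbers; the two-point step a 22-fold higher number from compound 2 to compound 3 (1.35 log units; beyond the scatter) sets compound 3 apart, and a 3.7-fold higher number from compound 1 to compound 3 (0.57 log units; beyond the scatter) confirms it as the weakest measured member. Compound 4 `O=C(O)Cc1sc(C(c2ccc(F)cc2)c2ccc(F)cc2)nc1-c1ccnc(N2CCCC2)c1` differs from compound 3 by pyrrolidin-1-yl in place of hydroxy on an aromatic carbon. Among the measured compounds shown here, the only step bearing on it is the hydroxy introduction, a 22-fold higher number from compound 2 to compound 3 (1.35 log units; beyond the scatter), which was large; the reverse of that move would recover the value of compound 2, but no measured step covers the incoming pyrrolidin-1-yl group. Compound 4 is therefore expected to land between the values of compound 2 and compound 3, with a 7.4-fold lower number from compound 3 to compound 4 (0.87 log units; beyond the scatter) as the estimated step, giving an estimate of 120 nM (range 25 nM to 600 nM).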

Compound 4, half-maximal inhibitory concentration: > 100000 nM
Compound 4: a limit, no number; the forecaster's own chance of this, stated with the estimate: 5%; middle value at least 830-fold (2.92 log units) away from the limit.
By their numbers in this assay, from the lowest: compound 2; then compound 1; then compound 3. At a limit, above all of these: compound 4.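

The value of compound 4 is a limit of the assay, not a number: the limit of > 100000 nM in this assay, at which 1 of the 4 values shown sits. On the aromatic carbon next to the ring nitrogen, neither hydroxy nor pyrrolidin-1-yl is tolerated, and the pyrrolidin-1-yl loss is the greater, with an at least 110-fold higher number from compound 3 to compound 4 (2.05 log units; beyond the scatter) and an at least 2500-fold higher number from compound 2 to compound 4 (3.39 log units; beyond the scatter). The change also erases the gain of the ring nitrogen over phenyl, with an at least 410-fold higher number from compound 1 to compound 4 (2.61 log units; beyond the scatter).

As far as these compounds go, whether a methyl, a methoxy or a fluorine at this position would hold the value of compound 2 stays open. So does whether an open-chain dimethylamino group would behave like the pyrrolidin-1-yl ring.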